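A chloro step from compound 1

The source may report more compounds than this note shows. Statements on the series, on what has been measured and on what is new or still open speak of the compounds shown alone.

In a functional assay on HCT-116 cells (Homo sapiens) for inhibition, read by MTT assay, with a stated time of 48 h (on this read-out lower numbers stand for stronger inhibition and higher numbers for weaker inhibition), compound 1 (`CC(C)(C)OC(=O)c1ccc(NC(=O)c2cccc(S(N)(=O)=O)c2)cc1`) gives 9820 nM and compound 2 (`COc1cc(NC(=O)c2cccc(S(N)(=O)=O)c2)cc(OC)c1OC`) gives 10700 nM. These two values lie within the scatter of each other, so compound 1 stands level with compound 2. Compound 3 (`CC(C)(C)OC(=O)c1ccc(NC(=O)c2ccc(Cl)c(S(N)(=O)=O)c2)cc1`) differs from compound 1 in one place: chloro in place of hydrogen on an aromatic carbon, ortho to a sulfamoyl group and para to a large group. Among the measured compounds shown here, no measured pair shows the effect of such a change, so only a small shift toward stronger inhibition is expected, scarcely beyond the scatter. The estimated step is a 1.4-fold lower number from compound 1 to compound 3 (0.15 log units; within the scatter). In this assay the expected value for compound 3 is 7000 nM, within a range of 2500 nM to 20000 nM.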

Compound 3, half-maximal inhibitory concentration in the HCT-116 assay: 690 nM
The estimate for compound 3 lay 10-fold (1.01 log units) above the measured number; the whole stated range lies above it.
By their numbers in the HCT-116 assay, from the lowest: compound 3; then compounds 1 and 2 (each within the scatter of the next).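

In the HCT-116 assay compound 1 gives 9820 nM and compound 3 gives 690 nM; chloro in place of hydrogen, ortho to a sulfamoyl group and para to a large group, gives a 14-fold lower number from compound 1 to compound 3 (1.15 log units; beyond the scatter), the only step among these compounds in this read-out. In a physicochemical assay for lipophilicity (a lower number here means a more polar compound, a higher number a more lipophilic compound), compound 1 gives 1.54 and compound 3 gives 1.83; the same change gives a number 0.29 log units higher from compound 1 to compound 3 (within the scatter), so the two read-outs do not move alike for this pair. Nothing measured here accounts for the step in cell inhibition.

Whether chloro itself matters stays open, since no compound shown carries fluoro, methyl or an amine at this carbon. Also open, on these data alone, is whether the same change would carry over to compound 2.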